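The source may hold more compounds than are shown below. What is called first, only, known or untested is meant among the compounds shown, and "the series" means these compounds.

Series notes on the shared core of compound 1 `CCNC(=O)Nc1ccc(-c2nc3n(Cc4c(F)cccc4F)cc(C(=O)OCC)c(=O)n3c2CN(C)Cc2ccccc2)cc1`. In a functional assay on CHO cells for antagonist activity at Gonadotropin-releasing hormone receptor (Homo sapiens), read by a luciferase reporter, with a stated time of 30 min (a higher number here means a weaker inhibitor, a lower number a stronger inhibitor), compound 1 gives 70.8 nM. Compound 2 `CCNC(=O)Nc1ccc(-c2nc3n(Cc4c(F)cccc4F)cc(C(=O)NCc4cn(CCOCCOCCN=[N+]=[N-])nn4)c(=O)n3c2CN(C)Cc2ccccc2)cc1` replaces the ethyl ester by an amide bearing a triazole chain. In this assay compound 2 reaches only a limit, < 10000 nM, so where it stands among the numbers is open. One of the two values sits at that limit (the limit of < 10000 nM in this assay, at which 1 of the 2 values shown sits). Compound 3 `CCNC(=O)Nc1ccc(-c2nc3n(Cc4c(F)cccc4F)cc(C(=O)NCc4cn(CCN=[N+]=[N-])nn4)c(=O)n3c2CN(C)Cc2ccccc2)cc1` shortens the chain: azido in place of 2-(2-azidoethoxy)ethoxy on a saturated chain carbon, two bonds along the chain from an aromatic nitrogen. Among the measured compounds shown here, no measured step covers this change, and with compound 2 known only as a limit, no shift beyond the scatter is expected in this assay; the step that the limit leaves unreadable from compound 2 to compound 3 is an estimate. Compound 3 is expected near 3000 nM, within 300 nM to 10000 nM, with a fair chance of another limit.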

Compound 3, half-maximal inhibitory concentration: < 10000 nM
Compound 3: no number, only a limit (the forecaster's own chance of this, stated with the estimate: 50%); the middle value is on the limit's open side.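

Compound 2 and compound 3 both give only a limit, so no step among compound 1, compound 2 and compound 3 can be read: the limit of < 10000 nM in this assay, at which 2 of the 3 values shown sit.

Still open, from the compounds shown here alone, is the true standing of compound 2 and compound 3 against compound 1, and whether the chain change between them matters.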